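The source may hold more compounds than are shown below. What is called first, only, known or untested is meant among the compounds shown, and "the series" means these compounds.

Measured so far in a functional assay on SW480 cells (Homo sapiens) for cytotoxicity, read by MTT assay, with a stated time of 4 days; a higher number here means a weaker inhibitor, a lower number a stronger inhibitor:

compound 1 `C=C1C(=O)[C@]23C[C@@]1(O)CC[C@H]2c1ccc(O)c(C)c1[C@@H]3Cn1cc(-c2ccccc2)nn1` gives 260 nM
compound 2 `C=C1C(=O)[C@]23C[C@@]1(O)CC[C@H]2c1ccc(O)c(C)c1[C@@H]3Cn1cc(-c2ccc(Br)cc2)nn1` gives 310 nM
compound 3 `C=C1C[C@]23C[C@@]1(O)CC[C@H]2c1ccc(O)c(C)c1[C@@H]3Cn1cc(-c2ccc(C)cc2)nn1` gives > 20000 nM, which is a limit of the assay rather than a number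

Compound 1 and compound 2 share one core and differ only in the phenyl ring hanging from the triazole: bromo in place of hydrogen on an aromatic carbon. This change gave a 1.2-fold higher number from compound 1 to compound 2 (0.08 log units; within the scatter), so the two values sit together and neither can be called the stronger of the pair.

Compound 3 is built on a different core, and the difference between the two cores is not broken down here. For compound 3 the assay reports only (the limit of > 20000 nM in this assay, at which 1 of the 3 values shown sits).

Compound 4, `C=C1C[C@]23C[C@@]1(O)CC[C@H]2c1cc(Br)c(O)c(C)c1[C@@H]3Cn1cc(-c2ccc(C)cc2)nn1`, has not yet been measured. It differs from compound 3 by the same kind of change as that from compound 1 to compound 2, bromo in place of hydrogen on an aromatic carbon, but at a different place: bromo in place of hydrogen on an aromatic carbon. The earlier bromo sat on the pendant phenyl, para to a large group; this one sits on the fused core ring, ortho to the hydroxy group and meta to the methyl group.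

For compound 4 the expected step is a number no higher from compound 3 to compound 4 (the limit leaves the size open), resting on compound 3 starting at the limit and on the earlier bromo step of a 1.2-fold higher number from compound 1 to compound 2 (0.08 log units; within the scatter) having stayed within the scatter. Compound 4 is therefore estimated at 20000 nM, within 5000 nM to 60000 nM, and most likely the assay will again report only a limit.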

Compound 4, half-maximal inhibitory concentration: > 20000 nM
Compound 4 ended at the assay's limit (the forecaster's own chance of this, stated with the estimate: 65%); the middle value sits exactly at the limit.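

In this assay, compound 3 and compound 4 both stand at a limit rather than at a number, so the step between them, bromo in place of hydrogen, cannot be read: the limit of > 20000 nM in this assay, at which 2 of the 4 values shown sit.

The compounds shown leave open whether bromo at this place would change the value of a compound on the core of compound 1, whose value is a true number.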